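A few compounds are considered here, and "the series" means these few. Any claim that something is new, unique, unknown or untested is made for them only; others in the source may bear on it.

Two nucleoside analogues have been measured so far. Compound 1 `CNc1nc(SC)nc2c1ncn2[C@@H]1C[C@@H](O)[C@H](CO)O1` carries a methylamino group and a methylsulfanyl group on its shared core; in a functional assay on PHA-Ly cells (Homo sapiens) (a higher number here means a weaker inhibitor, a lower number a stronger inhibitor), compound 1 gives 81 uM. Compound 2 `CN(C)c1nc(Br)nc2c1ncn2[C@@H]1C[C@@H](O)[C@H](CO)O1` carries a dimethylamino group and a bromo group instead, and in this assay compound 2 gives 88 uM. Compound 2 sits at the top of the two numbers, but its gap to compound 1 lies within the scatter, so the two cannot be told apart. Going by the values given here, the two compounds differ in two places, so no single step can be drawn between them.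

Compound 3 `CSc1nc(N(C)C)c2ncn([C@@H]3C[C@@H](O)[C@H](CO)O3)c2n1` keeps the dimethylamino group of compound 2 and introduces one change: methylsulfanyl in place of bromo on an aromatic carbon. Compound 1 already shows a methylsulfanyl group at this place giving 81 uM, and compound 2 with bromo gives 88 uM, so no step beyond the scatter is expected in this assay in either direction. The step from compound 2 to compound 3 is therefore expected to be a 1.0-fold higher number from compound 2 to compound 3 (0.01 log units; within the scatter). For compound 3 in this assay the estimate is 90 uM, with a range from 35 uM to 240 uM.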

Compound 3, concentration for 50% inhibition: 260 uM
Beside the measured number, compound 3's estimate is 2.9-fold (0.46 log units) below it; the whole stated range lies below it.
By their numbers in this assay, from the lowest: compounds 1 and 2 (each within the scatter of the next); then compound 3.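

In this assay, the aromatic carbon between two ring nitrogen atoms proves sensitive to the group it carries: with the dimethylamino group held constant, methylsulfanyl in place of bromo gives a 3.0-fold higher number from compound 2 to compound 3 (0.47 log units; beyond the scatter). The nitrogen on the aromatic ring is also sensitive, since with methylsulfanyl held constant, methyl in place of hydrogen on that nitrogen gives a 3.2-fold higher number from compound 1 to compound 3 (0.51 log units; beyond the scatter), a step of similar size that ends at the same compound. Each change thus moves toward a weaker inhibitor when read on its own, which the first two compounds could not show, but no measured property accounts for either step.

Going by these compounds alone, only one step has been read at each place, so it remains open whether the effect of methylsulfanyl in place of bromo would look the same with the methylamino group present, or whether the effect of the added methyl would look the same with bromo present. On these data alone, it is also open how a chloro group or an amine on the aromatic carbon, or a longer chain such as ethyl on the nitrogen, would compare in this assay.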